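This account rests on a few compounds, and the source may have more. Where it says the series, first, only, none or still open, it means among the compounds named here.

Three compounds have been run through an ADME assay on microsomes from liver (Rattus norvegicus) for metabolic stability, read by LC-MS, with a stated time of 1 h, at 37 degrees C, tested at 4 uM; on this read-out higher numbers stand for a more stable compound and lower numbers for a less stable compound. Compound 1 `O=C(O)c1cc(-c2cccc(COc3ccc4c(=O)n(C5CC5)sc4c3)c2)ccc1Cl` is the most stable of the three, with 86% remaining. Compound 3 `O=C(O)c1cc(-c2cccc(-c3ccc4c(c3)CN(C3CCCC3)C4=O)c2)ccc1Cl` follows with 70%. Compound 2 `Cc1ccc(C(=O)O)cc1-c1cccc(COc2ccc3c(c2)CN(C2CCCC2)C3=O)c1` stands lowest, at 2%, and both gaps to the other two lie beyond the scatter of repeated measurements: compound 3 sits clearly higher than compound 2, and compound 1 higher still.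

The next compound, compound 4 `O=C1c2ccc(OCc3cccc(-c4ccccc4)c3)cc2CN1C1CCCC1`, differs from compound 2 in one place. phenyl in place of 5-carboxy-2-methylphenyl on an aromatic carbon The rest of the shared core is kept unchanged.

Within the data shown here, no measured pair in this set shows what this particular swap does in this assay, so the expectation rests on the low starting point alone. Compound 4 is expected to remain a poorly stable compound, with a step of a number 4 percentage points higher from compound 2 to compound 4 (within the scatter) that is small and likely within the scatter, because compound 2 already sits at 2% and leaves little room to fall. Compound 4 is estimated at 6%, in a range from 0% to 25%.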

Compound 4, percent of the compound remaining: 38%
Beside the measured number, compound 4's estimate is 32 percentage points below it, outside the stated range (above it).
By their numbers in this assay, from the lowest: compound 2; then compound 4; then compound 3; then compound 1.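

Swapping 5-carboxy-2-methylphenyl for plain phenyl on this aromatic carbon gives, in this assay, a number 36 percentage points higher from compound 2 to compound 4 (beyond the scatter). This shows that the group at this position has a large effect on the read-out, and that the substituted ring of compound 2 is not needed for a higher number in this assay. The change removes the carboxylic acid and the methyl together, so the step cannot be assigned to either one, and no supporting data explain it.

On these data alone, it remains open whether a phenyl carrying only the carboxylic acid, or only the methyl, would read closer to compound 2 or to compound 4 in this assay. How a phenyl carrying an amine or a nitrile would behave at this same position is also unknown.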